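A few compounds are considered here, and "the series" means these few. Any claim that something is new, unique, unknown or untested is made for them only; others in the source may bear on it.

Compound 1 `Cc1cccc(Nc2nccc(-c3cc(C)oc3C)n2)c1` in a functional assay for inhibition, with Homo sapiens as the target (on this read-out lower numbers stand for stronger inhibition and higher numbers for weaker inhibition), gives 28500 nM. Compound 2 `Cc1cc(-c2ccco2)nc(Nc2ccc(N(C)C)cc2)n1` gives 5900 nM, and compound 3 `CN(C)c1ccc(Nc2nccc(-c3ccco3)n2)cc1` gives 1900 nM. Compound 3 and compound 2 differ in one place, (methyl in place of hydrogen on an aromatic carbon), and this change made a step of a 3.1-fold higher number from compound 3 to compound 2 (0.49 log units; beyond the scatter). How the core of compound 1 differs from that of compound 3 is not broken down here.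

Compound 4 `Cc1cc(C)cc(Nc2nccc(-c3cc(C)oc3C)n2)c1` is not yet measured. It differs from compound 1 by methyl in place of hydrogen on an aromatic carbon. This is the same kind of change as between compound 3 and compound 2, but not the same: there the methyl enters a six-membered aromatic ring with 2 nitrogen, next to the ring nitrogen and meta to a furan-2-yl group; here it enters a ring of carbon only, meta to a methyl group. Going from compound 1 to compound 4, a step of a 1.2-fold higher number from compound 1 to compound 4 (0.09 log units; within the scatter) is expected, resting on the earlier step of a 3.1-fold higher number from compound 3 to compound 2 (0.49 log units; beyond the scatter) from compound 3 to compound 2, weighed against the different surroundings of the change. Compound 4 is therefore estimated at 35000 nM, between 12000 nM and 100000 nM.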

Compound 4, half-maximal inhibitory concentration: 4100 nM
For compound 4 the middle estimate is 8.5-fold (0.93 log units) above the measured one; measured number below the stated range.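

In this assay, putting a methyl on the ring of carbon only gave a 7.0-fold lower number from compound 1 to compound 4 (0.84 log units; beyond the scatter), whereas the same kind of change on the other core raised the number, and the two steps clearly differ: the same change on two cores in this assay, a 3.1-fold higher number (0.49 log units; beyond the scatter) from compound 3 to compound 2 and a 7.0-fold lower number (0.84 log units; beyond the scatter) from compound 1 to compound 4, 22-fold (1.33 log units) apart, beyond the scatter of two such steps. The size and even the direction of this change therefore cannot be carried from one core to another in this series. The steps do not show why they differ, as the methyl enters a different ring on each core and the cores differ in more than that one place.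

The compounds shown leave open whether a larger or different group at the same place, such as an ethyl, a methoxy or a fluorine, would lower the number as methyl does on the core of compound 1.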